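Amide to Ester on the Ring Carbon

The source may hold more compounds than are shown below. What is called first, only, known or untested is meant among the compounds shown, and "the series" means these compounds.

Compound 1, `COc1ccc2c(c1)OC(c1cc(OC)c(OC)c(OC)c1)C(CO)=C2`: > 50000 nM
Compound 2, `COc1ccc2c(c1)OC(c1cc(OC)c(OC)c(OC)c1)C(C(=O)NC(C)(C)C)=C2`: 28400 nM
Compound 3, `CNC(=O)C1=Cc2ccc(OC)cc2OC1c1cc(OC)c(OC)c(OC)c1`: > 50000 nM

In a functional assay for inhibition of nuclear factor NF-kappa-B complex (Homo sapiens) (a lower number here means a stronger inhibitor, a higher number a weaker inhibitor), compound 1 gives > 50000 nM, which is a limit of the assay and not a number. Compound 2 gives 28400 nM. Compound 3 gives > 50000 nM, again a limit. Most of what is known sits at the limit of > 50000 nM in this assay, at which 2 of the 3 values shown sit, so only one number is on hand. The step of an at least 1.7-fold lower number from compound 1 to compound 2 (0.24 log units; that floor lies within the scatter) and the step of an at least 1.7-fold higher number from compound 2 to compound 3 (0.24 log units; that floor lies within the scatter) are both read against a limit, and the step that the two limits leave unreadable from compound 1 to compound 3 cannot be read at all.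

Compound 4, `COc1ccc2c(c1)OC(c1cc(OC)c(OC)c(OC)c1)C(C(=O)OC(C)(C)C)=C2`, differs from compound 3 by tert-butoxy in place of methylamino on a carbonyl carbon. The step that bears most on it is an at least 1.7-fold higher number from compound 2 to compound 3 (0.24 log units; that floor lies within the scatter), where a larger group on the carbonyl's neighbour went with a number rather than a limit. By analogy, compound 4 is expected to show a step of an at least 1.4-fold lower number from compound 3 to compound 4 (0.15 log units; that floor lies within the scatter), toward a readable value. Compound 4 is therefore estimated at 35000 nM, within 15000 nM to 80000 nM.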

Compound 4, half-maximal inhibitory concentration: 14100 nM
The estimate for compound 4 lay 2.5-fold (0.39 log units) above the measured number; measured number below the stated range.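

In this assay, for the compounds shown here, tert-butoxy in place of methylamino on the carbonyl carbon gives an at least 3.5-fold lower number from compound 3 to compound 4 (0.54 log units; beyond the scatter), the first step in this set to clear the scatter. Tert-butoxy in place of (tert-butyl)amino gives a 2.0-fold lower number from compound 2 to compound 4 (0.30 log units; within the scatter), so the two count as alike, and a readable value here does not depend on the amide hydrogen, which compound 4 lacks. Tert-butoxycarbonyl in place of hydroxymethyl gives an at least 3.5-fold lower number from compound 1 to compound 4 (0.54 log units; beyond the scatter), so the two compounds with a tert-butyl group both give numbers, while compound 1 and compound 3 remain limits of the assay.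

A methyl ester or a free carboxylic acid at this place would show whether the tert-butyl group or the ester link matters more. The step between compound 1 and compound 3 cannot be read, and part of the set still gives no number: the limit of > 50000 nM in this assay, at which 2 of the 4 values shown sit.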